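The source may report more compounds than this note shows. Statements on the series, on what has been measured and on what is new or still open speak of the compounds shown alone.

Measured compounds:
- compound 1, `CCc1cc(S(=O)(=O)N2C[C@H](c3ccccc3)NC2=O)ccc1NC(=O)OC(C)C`: 60 nM in a functional assay on NCI-H460 cells (Homo sapiens) for cytotoxicity, read by MTT assay; a higher number here means a weaker inhibitor, a lower number a stronger inhibitor
- compound 2, `CCOC(=O)Nc1c(C)cc(S(=O)(=O)N2C[C@H](c3ccccc3)NC2=O)cc1C`: in this assay compound 2 gives > 10000 nM, a limit of the assay and not a number
- compound 3, `CCOC(=O)Nc1ccc(S(=O)(=O)N2C[C@H](c3ccccc3)NC2=O)cc1Cl`: 20 nM in this assay

Compound 1 holds the higher of the two numbered values in this assay; compound 3 sits at a lower number, and that gap lies beyond the scatter. Compound 2 is recorded only at the limit of > 10000 nM in this assay, at which 1 of the 3 values shown sits.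

Compound 4, `CCc1cc(S(=O)(=O)N2C[C@H](c3ccccc3)NC2=O)ccc1NC(=O)NC(C)C`, is not yet measured. It differs from compound 1 by isopropylamino in place of isopropoxy on a carbonyl carbon. Within the data shown here, no measured pair in this set shows that change, so the size of the step has to be judged without a direct precedent; the carbamate is the only variant of this position among the numbered values, and the other substituent changes across compounds 1 and 3 move the number within a narrow band. The expectation is a small step, not beyond the scatter, with the direction open.

For compound 4 the expected value in this assay is 100 nM, with a range from 25 nM to 400 nM. The step from compound 1 to compound 4 is therefore estimated at a 1.7-fold higher number from compound 1 to compound 4 (0.22 log units; within the scatter).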

Compound 4, half-maximal inhibitory concentration: 70 nM
Beside the measured number, compound 4's estimate is 1.4-fold (0.15 log units) above it; the range from low to high includes it.
By their numbers in this assay, from the lowest: compound 3; then compounds 1 and 4 (each within the scatter of the next). At a limit, above all of these: compound 2.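

In this assay the exchange of isopropoxy for isopropylamino on a carbonyl carbon gives a 1.2-fold higher number from compound 1 to compound 4 (0.07 log units; within the scatter), the only direct reading of this position among the compounds shown. The oxygen can therefore give way to a nitrogen here, with a hydrogen-bond donor gained and a hydrogen-bond acceptor lost, and the two compounds still stand within the scatter of each other. No measured property in this set bears on this result.

Open, on these data alone, is how far the carbonyl carbon accepts other groups, such as methylamino, dimethylamino or a longer chain like n-butoxy. Compound 2 gives > 10000 nM, a limit of the assay and not a number, and it differs from compound 1 in more than one place, so it says nothing about this change.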